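Swapping an amino group for bromine on a shared core

The source may hold more compounds than are shown below. What is called first, only, known or untested is meant among the compounds shown, and "the series" means these compounds.

Two compounds share one core and differ only in the group on a six-membered aromatic ring of carbon only. Compound 1, `Cn1c(=O)[nH]c2c(cnn2-c2ccccc2N)c1=N`, carries an amino group there. In an assay on membranes from brain for binding affinity to adenosine receptor A1 (Rattus norvegicus), read by radioligand binding, tested at 20 uM (a lower number here means less inhibition, a higher number more inhibition at the concentration tested (going by the name of the read-out)), compound 1 gives 0%. Compound 2, `Cn1c(=O)[nH]c2c(cnn2-c2ccc([N+](=O)[O-])cc2)c1=N`, carries a nitro group on the same ring. In this assay compound 2 gives 5%. Compound 1 shows the lower of the two numbers, but the gap to compound 2 lies within the usual scatter of such measurements, so the two cannot be told apart; both show essentially no inhibition at the concentration tested.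

Compound 3, `Cn1c(=O)[nH]c2c(cnn2-c2ccccc2Br)c1=N`, is a new variant of compound 1. The change is bromo in place of amino on an aromatic carbon. For the measured compounds named here, no measured pair shows the effect of this swap, so no step size can be taken from the data. Since compound 1 gives 0% and compound 2 gives 5%, both low numbers, the expectation is that compound 3 gives a similarly low number, with a change of a number 5 percentage points higher from compound 1 to compound 3 (within the scatter) that is not beyond the scatter. Compound 3 is estimated to give 5%, between 0% and 20%.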

Compound 3, a percentage reported as inhibition, at one concentration (the size of the read-out at that concentration, not a potency): 6%
Compound 3: middle estimate off by 1 percentage points, on the low side, within the range that was stated.
By their numbers in this assay, from the lowest: compounds 1, 2 and 3 (each within the scatter of the next).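

In this assay, for the compounds shown here, bromo in place of amino on an aromatic carbon, ortho to a large group, gives a number 6 percentage points higher from compound 1 to compound 3 (within the scatter), the first direct comparison of two groups at this one place on the shared core. The amino group counts as a hydrogen-bond donor and acceptor while bromo counts as neither, yet this exchange does not produce a difference beyond the scatter, and compound 3, at 6%, still shows essentially no inhibition at the concentration tested. Nothing available explains this result or links it to any property of either group.

Going by these compounds alone, only two groups have been compared at this place, and both leave the read-out close to nothing, so it remains open whether any group there could produce clear inhibition in this assay. A methoxy group, a carboxylic acid or a longer alkyl chain on the same aromatic carbon would test this, and a clear value from any of them would show whether this place on the shared core can influence the result at all.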